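A few compounds are considered here, and "the series" means these few. Any claim that something is new, unique, unknown or untested is made for them only; others in the source may bear on it.

Compound 1 `Cc1cc(/C=C/C#N)cc(C)c1Oc1cc(Nc2ccc(C#N)cc2)c(N)cc1C(=O)NCCC(F)F`: 0.233 h
Compound 2 `Cc1cc(/C=C/C#N)cc(C)c1Oc1cc(Nc2ccc(C#N)cc2)c(N)cc1C(=O)N1CC1`: 2.63 h

In an ADME assay on microsomes from liver (Homo sapiens) for metabolic stability, read by LC-MS, using NADPH, with a stated time of 45 min, tested at 1 uM (on this read-out higher numbers stand for a longer-lived compound and lower numbers for a shorter-lived compound), compound 2 holds the higher of the two numbers; the only other one, that of compound 1, is separated from it by an 11-fold higher number from compound 1 to compound 2 (1.05 log units; beyond the scatter). Compound 3 `Cc1cc(/C=C/C#N)cc(C)c1Oc1cc(Nc2ccc(C#N)cc2)c(N)cc1C(=O)OCCC#N` differs from compound 2 by 2-cyanoethoxy in place of aziridin-1-yl on a carbonyl carbon. Among the compounds with values here, the one step that bears on this place, an 11-fold higher number from compound 1 to compound 2 (1.05 log units; beyond the scatter), was large and favoured the ring group that compound 3 now gives up for an open chain, as compound 1 also carries a chain there. A step downward is therefore expected, a 5.3-fold lower number from compound 2 to compound 3 (0.72 log units; beyond the scatter). Compound 3 is estimated at 0.5 h, with a range from 0.15 h to 1.6 h.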

Compound 3, half-life: 0.283 h
The estimate for compound 3 lay 1.8-fold (0.25 log units) above the measured number; low and high end bracket the measured number.
By their numbers in this assay, from the lowest: compounds 1 and 3 (each within the scatter of the next); then compound 2.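

In this assay, replacing aziridin-1-yl with 2-cyanoethoxy on the carbonyl carbon loses most of the longer life seen for compound 2 (a 9.3-fold lower number from compound 2 to compound 3 (0.97 log units; beyond the scatter)). The two open chains, which differ in atoms and length, cannot be told apart (a 1.2-fold higher number from compound 1 to compound 3 (0.08 log units; within the scatter)), so among these three compounds only the ring-bearing compound 2 stands out. No measurement here explains this difference. On these data alone, it remains open whether the higher number follows any ring or aziridin-1-yl alone; a pyrrolidine or a dimethylamine on the same carbonyl carbon would separate those possibilities.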